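Swapping a Hydroxy for Fluoro on the Side Chain

The source may report more compounds than this note shows. Statements on the series, on what has been measured and on what is new or still open speak of the compounds shown alone.

The two measured compounds share a core built from two hydroxy-methoxyphenyl rings joined at one saturated carbon. Compound 1 `COc1cc(C(c2ccc(O)c(OC)c2)[C@H](CC(C)C)C(C)C)ccc1O` carries a 1-isopropyl-3-methylbutyl group on that carbon, and in a functional assay on HeLa cells (Homo sapiens) for cytotoxicity, read by WST assay, with a stated time of 48 h (a higher number here means a weaker inhibitor, a lower number a stronger inhibitor), compound 1 gives 8200 nM. Compound 2 `COc1cc(C(c2ccc(O)c(OC)c2)[C@@H](CO)C(C)C)ccc1O` carries a shorter 1-(hydroxymethyl)-2-methylpropyl group instead. In this assay compound 2 gives > 100000 nM, which is a limit of the assay rather than a number; this is the limit of > 100000 nM in this assay, at which 1 of the 2 values shown sits. Within the data shown here, the single measured step, an at least 12-fold higher number from compound 1 to compound 2 (1.08 log units; beyond the scatter), shows that shortening the chain and adding the hydroxy together cost a great deal of activity.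

Compound 3 `COc1cc(C(c2ccc(O)c(OC)c2)[C@@H](CF)C(C)C)ccc1O` differs from compound 2 by a single atom: fluoro in place of hydroxy on a saturated chain carbon, three bonds along the chain from two aromatic carbons. Among the measured compounds shown here, no measured step isolates this particular exchange, since the only step that bears on this region mixed the hydroxy with a change in chain length. Compound 3 is therefore expected to stay weak, with at best a modest shift toward compound 1, so the estimated step of an at least 2.0-fold lower number from compound 2 to compound 3 (0.30 log units; that floor lies within the scatter) is small and uncertain. Compound 3 is estimated at 50000 nM, within 12000 nM to 200000 nM.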

Compound 3, half-maximal inhibitory concentration: 41000 nM
Compound 3: middle estimate off by 1.2-fold (0.09 log units), on the high side; measured number inside the range.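

Exchanging hydroxy for fluoro, with the rest of the side chain unchanged, gives in this assay an at least 2.4-fold lower number from compound 2 to compound 3 (0.38 log units; beyond the scatter), so this single atom matters on its own, which the earlier step could not show because it also changed the chain. From the compounds shown here alone, compound 2 gives > 100000 nM, which is a limit of the assay and not a number, so this step is only a floor and its full size stays unknown: the limit of > 100000 nM in this assay, at which 1 of the 3 values shown sits. Even without the hydroxy the weaker number remains, with a 5.0-fold higher number from compound 1 to compound 3 (0.70 log units; beyond the scatter), so the 1-(fluoromethyl)-2-methylpropyl group does not match the 1-isopropyl-3-methylbutyl group, and the side chain as a whole still counts.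

The compounds shown leave open whether the lower number follows the loss of the hydroxy or the arrival of the fluoro, a question on which a plain methyl, a chloromethyl or an aminomethyl in the same place would bear. They also leave open how the number would move with a longer chain ending in fluoro, which would show how much of the remaining gap to compound 1 follows chain length alone.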